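The compounds below may be only part of what the source reports. "The series", "measured", "known", "first", "only" and "open" are said of these compounds alone.

Measured in a functional assay on HeLa cells (Homo sapiens) for cytotoxicity, read by MTT assay, with a stated time of 48 h; a lower number here means a stronger inhibitor, a higher number a weaker inhibitor:
- compound 1 `COc1cc(COCc2cn(Cc3cc(C)cnc3Cl)nn2)cc(OC)c1OC`: 264000 nM
- compound 2 `COc1cc(-c2cc(COCc3cn(Cc4cc(-c5ccc(C)cc5)cnc4Cl)nn3)on2)cc(OC)c1OC`: 35300 nM
- compound 3 `COc1cc(C2CC(COCc3cn(Cc4cc(-c5ccc(F)cc5)cnc4Cl)nn3)ON2C=O)cc(OC)c1OC`: 27200 nM

Compound 1 is the weakest of the three, with both other compounds clearly lower. Compound 4 `COc1cc(COCc2cn(Cc3cc(-c4ccc(C)cc4)cnc3Cl)nn2)cc(OC)c1OC` is compound 1 with one change: 4-methylphenyl in place of methyl on an aromatic carbon. Compound 2 carries the same 4-methylphenyl group but also differs elsewhere, so its 35300 nM is only a rough guide. In this assay a move to a lower number is expected, beyond the scatter, probably not reaching compound 2. The estimated step is a 4.1-fold lower number from compound 1 to compound 4 (0.61 log units; beyond the scatter). For compound 4 the expected value is 65000 nM, with an estimated range of 25000 nM to 170000 nM.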

Compound 4, half-maximal inhibitory concentration: 28600 nM
The estimate for compound 4 lay 2.3-fold (0.36 log units) above the measured number; the range from low to high includes it.
By their numbers in this assay, from the lowest: compounds 3, 4 and 2 (each within the scatter of the next); then compound 1.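

In this assay, going by these compounds alone, 4-methylphenyl in place of methyl on the aromatic carbon para to a chloro group gives a 9.2-fold lower number from compound 1 to compound 4 (0.97 log units; beyond the scatter) as the only single-place comparison. Within the data shown here, with the rest of the core unchanged, this step belongs to this substitution alone, a separation that the earlier compounds, which differ in more than one place, did not allow. No measurement bearing on the origin of the step is available.

On these data alone, whether the step needs the whole 4-methylphenyl group or only its ring stays open. A plain phenyl, a 4-aminophenyl or an ethyl chain at this position would help to settle how the step depends on the group.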